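Moving the methoxy group around the ring on compound 2

The compounds below may be only part of what the source reports. "The series", "measured", "known", "first", "only" and "open" are said of these compounds alone.

Of the compounds shown here, three sharing one core have been measured in an assay on HEK293 cells for inhibition of Voltage-dependent T-type calcium channel subunit alpha-1G (Homo sapiens), read by fluorescence, tested at 10 uM; on this read-out higher numbers stand for more inhibition at the one concentration tested (going by the name of the read-out) and lower numbers for less inhibition. Compound 1 `CCCc1nc(-c2ccccc2)c(CNCCCN2CCN(c3ccccc3)CC2)o1` gives 43.7%, compound 2 `CCCc1nc(-c2ccccc2)c(CNCCCN2CCN(c3cccc(OC)c3)CC2)o1` gives 36.4%, and compound 3 `CCCc1nc(-c2ccccc2)c(CNCCN2CCN(c3ccccc3Cl)CC2)o1` gives 60.1%. Compound 2 thus lies within the scatter of compound 1, while compound 3, which differs from it in more than one place, stands beyond the scatter above it.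

The next compound, compound 4 `CCCc1nc(-c2ccccc2)c(CNCCCN2CCN(c3ccccc3OC)CC2)o1`, keeps every atom of compound 2 and joins them differently: 2-methoxyphenyl in place of 3-methoxyphenyl on an amine nitrogen in a ring. Within the data shown here, only one measured step bears on the methoxy group at all: adding it to the ring, a number 7.3 percentage points lower from compound 1 to compound 2 (within the scatter), a step within the scatter. Among the measured compounds shown here, no measured pair shows what moving the methoxy group from one ring position to another does, and the higher number of compound 3 cannot be tied to any single change, so it offers no guide here.

For the measured compounds named here, with the one relevant step inside the scatter, the step from compound 2 to compound 4 is expected to be no larger, estimated at a number 5.6 percentage points higher from compound 2 to compound 4 (within the scatter). Compound 4 is therefore expected to give about 42% in this assay, with a range from 25% to 60%.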

Compound 4, a percentage reported as inhibition, at one concentration (the size of the read-out at that concentration, not a potency): 41%
Estimate against measurement, compound 4: 1 percentage points above; low and high end bracket the measured number.
By their numbers in this assay, from the lowest: compounds 2, 4 and 1 (each within the scatter of the next); then compound 3.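

In this assay, the only measured move of the methoxy group around the ring, from 3-methoxyphenyl to 2-methoxyphenyl on the amine nitrogen in the ring, gives a number 4.6 percentage points higher from compound 2 to compound 4 (within the scatter), so these two placements cannot be told apart on this read-out. Replacing the plain phenyl group with 2-methoxyphenyl gives a number 2.7 percentage points lower from compound 1 to compound 4 (within the scatter), so in these three compounds neither placement of the methoxy group moves the number beyond the usual scatter of the measurement. No measurement at hand speaks to the reason for this outcome.

As far as these compounds go, what a different group on the same ring would do, such as a nitrile or a trifluoromethyl group in place of the methoxy group, remains open. Also open, from the compounds shown here alone, is whether the higher number of compound 3 belongs to its chlorine, its chain or both, since compound 3 differs from the other compounds in more than one place.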